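The source may report more compounds than this note shows. Statements on the series, on what has been measured and on what is new or still open speak of the compounds shown alone.

Compound 3 `C[C@@]12C[C@@H]1CC(COc1cccnc1)N2` is a pyridyl ether on a bicyclic amine core, and in an assay on CHO-K1 cells for displacement of a labelled ligand from Neuronal acetylcholine receptor; alpha4/beta2 (Homo sapiens), read by scintillation counting (on this read-out lower numbers stand for stronger inhibition and higher numbers for weaker inhibition), compound 3 gives 3.6 nM. Compound 1 `C[C@@]12C[C@@H]1CC(COc1cccnc1Cl)N2` carries the change (chloro in place of hydrogen on an aromatic carbon). In this assay compound 1 reaches only the limit of > 10000 nM, a limit and not a number, as noted in the limit of > 10000 nM in this assay, at which 1 of the 3 values shown sits. The step is therefore an at least 2700-fold higher number from compound 3 to compound 1 (3.44 log units; beyond the scatter). Compound 2 `c1cncc(OC[C@]23C[C@H]2CCN3)c1` has a different core; how the cores of compound 2 and compound 3 differ is not broken down here, and in this assay compound 2 gives 242 nM. Compound 4 `Clc1cncc(OC[C@]23C[C@H]2CCN3)c1` is derived from compound 2 by chloro in place of hydrogen on an aromatic carbon. This is the same kind of change as from compound 3 to compound 1, but the place differs: in compound 1 the chloro is next to the ring nitrogen and ortho to a group of 9 heavy atoms, whereas in compound 4 it is two atoms from the ring nitrogen and meta to a group of 8 heavy atoms. Because the measured step of an at least 2700-fold higher number from compound 3 to compound 1 (3.44 log units; beyond the scatter) concerns a different place, a smaller step is expected here, and compound 4 is estimated at 600 nM, between 100 nM and 5000 nM, a step of a 2.5-fold higher number from compound 2 to compound 4 (0.39 log units; beyond the scatter).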

Compound 4, inhibition constant: 827 nM
For compound 4 the middle estimate is 1.4-fold (0.14 log units) below the measured one, and the stated range covers the measured number.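

On the core of compound 2 the chloro in place of hydrogen gives a far smaller change in this assay than on the core of compound 3, with a 3.4-fold higher number from compound 2 to compound 4 (0.53 log units; beyond the scatter) here, so the size of this step does not carry over from one pair to the other: the same change on two cores in this assay, an at least 2700-fold higher number (3.44 log units; beyond the scatter) from compound 3 to compound 1 and a 3.4-fold higher number (0.53 log units; beyond the scatter) from compound 2 to compound 4, at least 810-fold (2.91 log units) apart, beyond the scatter of two such steps. Compound 1 gives > 10000 nM which is a limit and not a number, so the larger step has no known upper end: the limit of > 10000 nM in this assay, at which 1 of the 4 values shown sits. This does not show that the core alone sets the size of the step, as in compound 4 the chloro sits two atoms from the ring nitrogen, in compound 1 it sits at another place on the ring, and no pair shown has the same place on both cores.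

Still open, going by these compounds, is how the chloro would fare at one and the same place on both cores. Also open, on these data alone, is whether a fluoro, a methoxy or an amine at these places would follow the same course.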